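This account rests on a few compounds, and the source may have more. Where it says the series, first, only, none or still open, it means among the compounds named here.

Compound 1 `O=C(NCc1ccc(CNS(=O)(=O)c2cccc3ccccc23)cc1)c1ccc(CNc2ncccn2)cc1` gives 1000 nM in an assay on MDA-MB-231 cells for binding affinity to C-X-C chemokine receptor type 4 (Homo sapiens), read by microscopy, with stated times of 10 min and 30 min; a lower number here means that less compound is needed, a higher number that more compound is needed for the effect. Compound 2 `O=C(NCc1ccc(CNS(=O)(=O)c2ccc(-c3ccc(F)cc3)cc2)cc1)c1ccc(CNc2ncccn2)cc1` gives 1000 nM in this assay.

On these numbers compound 1 stands level with compound 2; the two values lie within the usual scatter of each other, so neither can be called stronger. Compound 3 `O=C(NCc1ccc(CNS(=O)(=O)c2ccc3c(c2)CCO3)cc1)c1ccc(CNc2ncccn2)cc1` differs from compound 1 in one place: a group of 9 heavy atoms (8 carbon, 1 oxygen; one five-membered non-aromatic ring with 1 hetero atom, one six-membered aromatic ring of carbon only) in place of a group of 10 heavy atoms (10 carbon; 2 six-membered aromatic rings of carbon only), on a sulfonyl sulfur. Among the compounds with values here, no measured pair shows a single change of this kind, so there is no measured step to lean on. The step of no change at the digits printed from compound 1 to compound 3 (within the scatter) is expected to stay within the scatter, in no clear direction. Compound 3 is therefore estimated at 1000 nM, with a range from 400 nM to 2500 nM.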

Compound 3, effective concentration (reported as EC, without a stated level of effect): 1000 nM
For compound 3 middle estimate and measured number coincide at the digits printed, within the range that was stated.
By their numbers in this assay, from the lowest: compounds 1, 2 and 3 (each within the scatter of the next).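

Within the data shown here, the step of no change at the digits printed from compound 1 to compound 3 (within the scatter) in this assay is the first direct comparison at this position, on a sulfonyl sulfur. Here naphthalen-1-yl, with two aromatic rings and no hydrogen-bond acceptor, gives way to a group with one aromatic ring, one five-membered non-aromatic ring and one hydrogen-bond acceptor, and the number stays level. No measurement shown here explains this result.

From the compounds shown here alone, whether a group carrying an amine or a carboxylic acid on that sulfur would shift the number remains open. So does the effect of changes elsewhere in the shared core.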